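This account rests on a few compounds, and the source may have more. Where it says the series, first, only, none or still open, it means among the compounds named here.

Three compounds have been measured:
compound 1, `CCC(C)(C)Cc1c[nH]c(CCc2ccc(-c3cccc(N)n3)cc2)n1`: 37 nM
compound 2, `CCC(C)(C)Cc1c[nH]c(CCc2ccc(-c3cccnc3)cc2)n1`: 131 nM
compound 3, `CCC(C)(C)Cc1c[nH]c(CCc2ccc(-c3ccc(F)cn3)cc2)n1`: 66 nM

All three share one core and differ only in the six-membered ring attached to an aromatic carbon of that core. In a functional assay on HEK293 cells for agonist activity at Bombesin receptor subtype-3 (Homo sapiens), read by luminescence and calcium flux, with a stated time of 10 min (on this read-out higher numbers stand for an effect only at larger amounts of compound and lower numbers for an effect already at smaller amounts), compound 1 gives the lowest of the three numbers; compound 3 lies close, as a 1.8-fold higher number from compound 1 to compound 3 (0.25 log units; within the scatter) stays within the scatter, while compound 2 lies further off, a 3.5-fold higher number from compound 1 to compound 2 (0.55 log units; beyond the scatter). Compound 4, `CCC(C)(C)Cc1c[nH]c(CCc2ccc(-c3cccnc3C(=O)O)cc2)n1`, has not been measured yet. Relative to compound 1 it carries 2-carboxypyridin-3-yl in place of 6-aminopyridin-2-yl on an aromatic carbon. Within the data shown here, two measured steps bear on this change. Among the measured compounds shown here, the first is the exchange of 6-aminopyridin-2-yl for pyridin-3-yl, a 3.5-fold higher number from compound 1 to compound 2 (0.55 log units; beyond the scatter), a modest step beyond the scatter. The second, a 1.8-fold higher number from compound 1 to compound 3 (0.25 log units; within the scatter), stays within the scatter. For the measured compounds named here, compound 4 keeps the pyridin-3-yl attachment of compound 2 and adds a carboxylic acid; nothing among the measured compounds shows what such an acid does here. The step of a 5.4-fold higher number from compound 1 to compound 4 (0.73 log units; beyond the scatter) is therefore expected to go toward a higher number, with wide uncertainty. Compound 4 is expected to give about 200 nM in this assay. The range for compound 4 is estimated to run from 50 nM to 800 nM.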

Compound 4, half-maximal effective concentration: 1260 nM
Beside the measured number, compound 4's estimate is 6.3-fold (0.80 log units) below it; measured number outside the range, above it.
By their numbers in this assay, from the lowest: compounds 1, 3 and 2 (each within the scatter of the next, the first and the last beyond it); then compound 4.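

The cleanest comparison in this assay is the one in which a single hydrogen gives way to carboxy, a 9.6-fold higher number from compound 2 to compound 4 (0.98 log units; beyond the scatter), so that one added group on the ring attached to the shared core means that far more compound is needed for the same effect. The earlier exchanges among compounds 1, 2 and 3 were modest or within the scatter, which made this place look forgiving; the 2-carboxypyridin-3-yl ring shows that it is not, with a 34-fold higher number from compound 1 to compound 4 (1.53 log units; beyond the scatter) and a 19-fold higher number from compound 3 to compound 4 (1.28 log units; beyond the scatter), both large steps. Nothing available here gives a reason for this loss.

On these data alone, it remains open whether the loss belongs to the carboxy group as such, which a methyl ester, a primary amide or a hydroxymethyl group in its place would help to tell. As far as these compounds go, it is equally open whether a carboxy group elsewhere on the pyridine ring, or on the 6-aminopyridin-2-yl ring of compound 1, would cost as much.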